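The source may hold more compounds than are shown below. What is called first, only, known or untested is meant among the compounds shown, and "the series" means these compounds.

Measured compounds:
compound 1 `CC(O)(C(=O)Nc1ccc(S(=O)(=O)c2ccccc2F)cc1)C(F)(F)F` — 1300 nM
compound 2 `CC(O)(C(=O)Nc1ccc(S(=O)(=O)c2ccccc2O)cc1)C(F)(F)F` — 3090 nM
compound 3 `CC(O)(C(=O)Nc1ccc(S(=O)(=O)c2cccc(O)c2)cc1)C(F)(F)F` — 18000 nM

In a functional assay (Cavia porcellus) with sulfonylurea receptors; K-ATP channels (Homo sapiens) as the target (on this read-out higher numbers stand for weaker inhibition and lower numbers for stronger inhibition), compound 3 stands highest of the three numbers. Its nearest neighbour is compound 2, at a 5.8-fold higher number from compound 2 to compound 3 (0.77 log units; beyond the scatter), and its furthest is compound 1, at a 14-fold higher number from compound 1 to compound 3 (1.14 log units; beyond the scatter). The step from compound 1 to compound 2 was smaller: a 2.4-fold higher number from compound 1 to compound 2 (0.38 log units; beyond the scatter).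

Compound 4 `COc1ccccc1S(=O)(=O)c1ccc(NC(=O)C(C)(O)C(F)(F)F)cc1` has not yet been measured. The change is 2-methoxyphenyl in place of 3-hydroxyphenyl on a sulfonyl sulfur. Two of the measured steps bear on it. The move from a 2-substituted to a 3-substituted phenyl on the sulfonyl sulfur, seen in a 5.8-fold higher number from compound 2 to compound 3 (0.77 log units; beyond the scatter), is reversed here, and the loss of the hydroxy group, a donor, points toward compound 1, whose 2-fluorophenyl analogue gives 1300 nM in this assay. Both steps beyond the scatter suggest a lower number for compound 4. The expected step is a 7.2-fold lower number from compound 3 to compound 4 (0.86 log units; beyond the scatter). Compound 4 is therefore estimated at 2500 nM in this assay, with a range from 800 nM to 8000 nM.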

Compound 4, half-maximal inhibitory concentration: 1600 nM
Compound 4: middle estimate off by 1.6-fold (0.19 log units), on the high side; the range from low to high includes it.
By their numbers in this assay, from the lowest: compounds 1, 4 and 2 (each within the scatter of the next, the first and the last beyond it); then compound 3.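

In this assay, the 2-methoxyphenyl group on the sulfonyl sulfur stands far from 3-hydroxyphenyl, with an 11-fold lower number from compound 3 to compound 4 (1.05 log units; beyond the scatter), although the hydroxy donor is gone from compound 4. Compound 4 cannot be told apart from either of its 2-substituted neighbours, with a 1.9-fold lower number from compound 2 to compound 4 (0.29 log units; within the scatter) and a 1.2-fold higher number from compound 1 to compound 4 (0.09 log units; within the scatter), so methyl on the oxygen and methoxy in place of fluoro both leave the read-out within the scatter, even though compound 1 and compound 2 are themselves separated beyond it. Nothing measured here accounts for these steps.

The compounds shown leave open how much of the large step belongs to the place of the substituent on the ring and how much to the methyl on oxygen, since the two change together. They also leave open how an amine or a longer ether chain in place of the methoxy would read.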